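This account rests on a few compounds, and the source may have more. Where it says the series, first, only, none or still open, it means among the compounds named here.

Of the compounds shown here, three share one core and have been measured. In a functional assay on ECV-304 cells (Homo sapiens), with stated times of 30 min and 6 h (on this read-out higher numbers stand for an effect only at larger amounts of compound and lower numbers for an effect already at smaller amounts), compound 1 `Cc1nc(C)c(CN2CCN(C(=O)c3cccnc3)CC2)nc1C` gives 220000 nM, compound 2 `Cc1nc(C)c(CN2CCN(C(=O)CCc3ccccc3)CC2)nc1C` gives 150000 nM, and compound 3 `Cc1nc(C)c(CN2CCN(S(C)(=O)=O)CC2)nc1C` gives 162000 nM. Compound 3 therefore stands among three numbers that all lie within the scatter of one another, as a 1.4-fold lower number from compound 1 to compound 3 (0.13 log units; within the scatter) and a 1.5-fold lower number from compound 1 to compound 2 (0.17 log units; within the scatter) show. Compound 4 `CCOC(=O)N1CCN(Cc2nc(C)c(C)nc2C)CC1` carries the change (ethoxycarbonyl in place of methylsulfonyl on an amine nitrogen in a ring). The measured step that bears most on this change is a 1.4-fold lower number from compound 1 to compound 3 (0.13 log units; within the scatter), and a 1.5-fold lower number from compound 1 to compound 2 (0.17 log units; within the scatter) was equally small, so no step beyond the scatter is expected in this assay from this exchange. Compound 4 is accordingly estimated at 170000 nM, within a range from 70000 nM to 400000 nM, which would mean an expected 1.0-fold higher number from compound 3 to compound 4 (0.02 log units; within the scatter).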

Compound 4, half-maximal effective concentration: 76600 nM
Compound 4: the middle estimate sits 2.2-fold (0.35 log units) above what was measured, within the range that was stated.
By their numbers in this assay, from the lowest: compounds 4, 2, 3 and 1 (each within the scatter of the next, the first and the last beyond it).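

With a 2.1-fold lower number from compound 3 to compound 4 (0.33 log units; beyond the scatter) and a 2.9-fold lower number from compound 1 to compound 4 (0.46 log units; beyond the scatter) both modest, ethoxycarbonyl on this amine nitrogen in a ring gives the first steps beyond the scatter in this assay among these compounds, yet a 2.0-fold lower number from compound 2 to compound 4 (0.29 log units; within the scatter) stays within it. The position can therefore respond to the group placed on it, but compound 4 is not set apart from every group there. On these data alone, whether a longer alkoxy chain such as butoxy, or a dimethylaminocarbonyl group, on the same nitrogen would lower the number further remains open. Nothing at hand explains these steps.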